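Swapping oxetan-3-yl for methyl on a ring amine nitrogen

The compounds below may be only part of what the source reports. "The series", "measured", "known", "first", "only" and "open" are said of these compounds alone.

Of the compounds shown here, three sharing one core have been measured in a physicochemical assay for solubility, in phosphate buffer, with a stated time of 24 h, at pH 7.4, tested at 100 uM; on this read-out higher numbers stand for higher solubility and lower numbers for lower solubility. Compound 1 `O=C(NCc1ccc(S(=O)(=O)C2CCC(F)(F)CC2)cc1)N1Cc2ccncc2C1`, with 4,4-difluorocyclohexyl on the sulfonyl sulfur, gives 35000 nM. Compound 2 `CC(=O)N1CCC(S(=O)(=O)c2ccc(CNC(=O)N3Cc4ccncc4C3)cc2)CC1`, with 1-acetylpiperidin-4-yl at that sulfur, gives 187000 nM. Compound 3 `O=C(NCc1ccc(S(=O)(=O)C2CCN(C3COC3)CC2)cc1)N1Cc2ccncc2C1`, with 1-(oxetan-3-yl)piperidin-4-yl there, gives 121000 nM. That number stands well clear of compound 1 and within the scatter of compound 2.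

Compound 4 `CN1CCC(S(=O)(=O)c2ccc(CNC(=O)N3Cc4ccncc4C3)cc2)CC1` carries methyl in place of oxetan-3-yl on an amine nitrogen in a ring, (methyl in place of oxetan-3-yl on an amine nitrogen in a ring). The nearest evidence is the swap at that same nitrogen, a 1.5-fold lower number from compound 2 to compound 3 (0.19 log units; within the scatter), which stayed within the scatter. The two larger steps, a 5.3-fold higher number from compound 1 to compound 2 (0.73 log units; beyond the scatter) and a 3.5-fold higher number from compound 1 to compound 3 (0.54 log units; beyond the scatter), were modest, and both removed the 4,4-difluorocyclohexyl group, which is also absent from compound 4. Among the compounds with values here, no measured compound carries methyl at this nitrogen, so the support is indirect. No step beyond the scatter is therefore expected in this assay. The expected step is a 1.2-fold higher number from compound 3 to compound 4 (0.06 log units; within the scatter). For compound 4 the estimated value is 140000 nM, with an expected range from 75000 nM to 260000 nM.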

Compound 4, solubility: 240000 nM
The estimate for compound 4 lay 1.7-fold (0.23 log units) below the measured number, and the stated range covers the measured number.
By their numbers in this assay, from the lowest: compound 1; then compounds 3, 2 and 4 (each within the scatter of the next).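

In this assay the amine nitrogen of the six-membered ring now carries methyl as well as oxetan-3-yl and acetyl, and neither a 2.0-fold higher number from compound 3 to compound 4 (0.30 log units; within the scatter) nor a 1.3-fold higher number from compound 2 to compound 4 (0.11 log units; within the scatter) lies beyond the scatter, so exchanging the four-membered ring of oxetan-3-yl, with its 4 heavy atoms, for the single carbon of methyl does not separate these compounds on this read-out. The one step here beyond the scatter is at the sulfonyl sulfur, where a 6.9-fold higher number from compound 1 to compound 4 (0.84 log units; beyond the scatter) is modest and leaves compound 1 apart from compound 4, as it already stood apart from compound 2 and compound 3, so among these compounds the measurable difference follows the exchange of 4,4-difluorocyclohexyl and not the choice of group on the nitrogen. Nothing measured here explains why the numbers fall as they do.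

As far as these compounds go, what remains open is whether a group of another kind on this nitrogen, such as a carboxylic acid, a longer alkyl chain or a plain hydrogen, would give a step beyond the scatter. From the compounds shown here alone, it is also open whether an unsubstituted cyclohexyl on the sulfonyl sulfur would stay near compound 1 or join the other three compounds.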